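Aryl ether variation in a small antiproliferative series

The compounds below may be only part of what the source reports. "The series", "measured", "known", "first", "only" and "open" are said of these compounds alone.

Measured compounds:
compound 1 `Cc1nn(C)c(Oc2ccc(F)cc2)c1/C=N\CCCCCCOc1cc2oc(=O)cc(C)c2cc1Cl`: 12500 nM
compound 2 `Cc1nn(C)c(Oc2cccc(Br)c2)c1/C=N\CCCCCCOc1cc2oc(=O)cc(C)c2cc1Cl`: 6830 nM

In a functional assay on HepG2 cells (Homo sapiens) for antiproliferative activity, read by MTT assay, with a stated time of 72 h (on this read-out higher numbers stand for weaker inhibition and lower numbers for stronger inhibition), compound 1 gives 12500 nM, and compound 2 gives 6830 nM. Going by the values given here, compound 2 holds the lower of the two numbers, but the only measured step, a 1.8-fold lower number from compound 1 to compound 2 (0.26 log units; within the scatter), lies within the scatter, so the two compounds cannot be ordered on these data.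

Compound 3 `Cc1ccc(Oc2c(/C=N\CCCCCCOc3cc4oc(=O)cc(C)c4cc3Cl)c(C)nn2C)cc1` differs from compound 2 by 4-methylphenyl in place of 3-bromophenyl on an oxygen on an aromatic ring. Among the compounds with values here, the single step that bears on this position is a 1.8-fold lower number from compound 1 to compound 2 (0.26 log units; within the scatter); it was within the scatter, and no measured pair covers 4-methylphenyl at this place. Nothing here points to a change beyond the scatter, so the step of a 1.2-fold higher number from compound 2 to compound 3 (0.07 log units; within the scatter) is expected to stay within it. Compound 3 is estimated at 8000 nM in this assay, within a range of 3000 nM to 22000 nM.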

Compound 3, half-maximal inhibitory concentration: 20700 nM
For compound 3 the middle estimate is 2.6-fold (0.41 log units) below the measured one; measured number inside the range.
By their numbers in this assay, from the lowest: compounds 2, 1 and 3 (each within the scatter of the next, the first and the last beyond it).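

In this assay the group on the ether oxygen now produces a change that clears the scatter, with a 3.0-fold higher number from compound 2 to compound 3 (0.48 log units; beyond the scatter); the earlier pair showed no such separation, so this position is not silent to every aryl change. Methyl in place of fluoro on the aromatic carbon gives only a 1.7-fold higher number from compound 1 to compound 3 (0.22 log units; within the scatter), which leaves compound 1 and compound 3 unordered. Compound 1 also remains within the scatter of compound 2, so only the 3-bromophenyl and 4-methylphenyl groups are separated here.

From the compounds shown here alone, the step from compound 2 to compound 3 changes both the substituent and its place on the ring, and it remains open which of the two carries the gap. Also open, going by these compounds, is how an unsubstituted phenyl, a methoxy group or an amine on this ring would read. No measurement at hand offers an explanation for the gap.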